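The compounds below may be only part of what the source reports. "The series", "measured", "known", "first", "only" and "open" are said of these compounds alone.

Compound 1 `C[C@@H](O[C@H]1CN2C(=O)C=C(c3ccccc3)CC2[C@@H]1c1ccc(F)cc1)c1cc(C(F)(F)F)cc(C(F)(F)F)c1` is the starting point of this small set: in an assay on CHO cells for displacement of a labelled ligand from Substance-P receptor (Homo sapiens) (a lower number here means a stronger inhibitor, a higher number a weaker inhibitor), compound 1 gives 0.93 nM. Within the data shown here, compound 2 `C[C@@H](O[C@H]1CN2C(=O)C=C(c3ccc[n+]([O-])c3)CC2[C@@H]1c1ccc(F)cc1)c1cc(C(F)(F)F)cc(C(F)(F)F)c1` differs from it at one place, and in this assay compound 2 gives 0.15 nM; the step of a 6.2-fold lower number from compound 1 to compound 2 (0.79 log units; beyond the scatter) is the only measured one, and it leaves compound 2 with the lowest of the two numbers, with compound 1 as its only neighbour. Compound 3 `C[C@@H](O[C@H]1CN2C(=O)C=C(c3cnn(C)c3)CC2[C@@H]1c1ccc(F)cc1)c1cc(C(F)(F)F)cc(C(F)(F)F)c1` takes the change (a group of 6 heavy atoms (4 carbon, 2 nitrogen; one five-membered aromatic ring with 2 hetero atoms) in place of a group of 7 heavy atoms (5 carbon, 1 nitrogen, 1 oxygen; one six-membered aromatic ring with 1 hetero atom), on a double-bonded ring carbon). Among the measured compounds shown here, no measured pair shows the same exchange; the only step that bears on it is a 6.2-fold lower number from compound 1 to compound 2 (0.79 log units; beyond the scatter), which showed that the group on the double-bonded ring carbon can move the number well beyond the scatter. Because that step a 6.2-fold lower number from compound 1 to compound 2 (0.79 log units; beyond the scatter) favoured the group that now leaves, compound 3 is expected to show a moderate rise in this assay, a 3.0-fold higher number from compound 2 to compound 3 (0.48 log units; beyond the scatter). Compound 3 is therefore estimated at 0.45 nM, within 0.15 nM to 1.4 nM.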

Compound 3, half-maximal inhibitory concentration: 0.13 nM
The estimate for compound 3 lay 3.5-fold (0.54 log units) above the measured number; the measured number lies below the stated range.
By their numbers in this assay, from the lowest: compounds 3 and 2 (each within the scatter of the next); then compound 1.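

The step of a 1.2-fold lower number from compound 2 to compound 3 (0.06 log units; within the scatter) in this assay shows that, on the double-bonded ring carbon, 1-methyl-1H-pyrazol-4-yl can stand in for the six-membered aromatic ring with one hetero atom, so the low number of compound 2 is not tied to that one group. The step of a 7.2-fold lower number from compound 1 to compound 3 (0.85 log units; beyond the scatter), with 1-methyl-1H-pyrazol-4-yl in place of phenyl, means that two different aromatic rings bearing hetero atoms now stand apart from phenyl at this position, each beyond the scatter. Nothing available here explains this difference from phenyl.

The compounds shown leave open how a morpholine, a carboxylic acid or a pyrazole without its methyl group would fare on this carbon. They also leave open whether this exchange would behave the same way on a different core.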